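Trifluoromethyl for methyl on a benzamide thiophene core

A few compounds are considered here, and "the series" means these few. Any claim that something is new, unique, unknown or untested is made for them only; others in the source may bear on it.

Measured compounds:
compound 1, `CCOC(=O)c1sc2ccc(NCc3nc[nH]c3C)cc2c1NC(=O)c1ccc(C(F)(F)F)cc1`, 12800 nM
compound 2, `CCOC(=O)c1sc2ccc(N)cc2c1NC(=O)c1ccc(C)cc1`, 24400 nM

In a functional assay on HeLa cells (Homo sapiens) for antiproliferative activity, read by MTT assay, with a stated time of 48 h (a lower number here means a stronger inhibitor of growth, a higher number a weaker inhibitor of growth), compound 2 gives 24400 nM, the higher of the two numbers seen so far. Compound 1 gives 12800 nM, and the two numbers lie within the scatter of each other, so neither compound can be called the stronger inhibitor of growth on this evidence. Compound 3, `CCOC(=O)c1sc2ccc(N)cc2c1NC(=O)c1ccc(C(F)(F)F)cc1`, keeps the free amine of compound 2 and differs from it in one place: trifluoromethyl in place of methyl on an aromatic carbon. Within the data shown here, no pair among the measured compounds shows this change on its own, and compound 1 differs from compound 3 in a second place as well, so no single step tells what to expect. The change is expected to leave this assay close to where compound 2 stands, with at most a modest move toward a lower number, estimated as a 1.4-fold lower number from compound 2 to compound 3 (0.13 log units; within the scatter). Compound 3 is therefore estimated at 18000 nM, with a range from 6000 nM to 50000 nM.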

Compound 3, concentration for 50% growth inhibition: 6680 nM
Beside the measured number, compound 3's estimate is 2.7-fold (0.43 log units) above it, and the stated range covers the measured number.
By their numbers in this assay, from the lowest: compounds 3, 1 and 2 (each within the scatter of the next, the first and the last beyond it).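

With the free amine kept, trifluoromethyl in place of methyl on an aromatic carbon para to a large group gives a 3.7-fold lower number from compound 2 to compound 3 (0.56 log units; beyond the scatter) in this assay and so shows that this position responds to the change, though only modestly. The other single change, hydrogen in place of (5-methyl-1H-imidazol-4-yl)methyl on the nitrogen, gives a 1.9-fold lower number from compound 1 to compound 3 (0.28 log units; within the scatter) and so does not separate these two groups when trifluoromethyl is present. No measurement shown offers a reason for the step at the trifluoromethyl position.

On these data alone, whether the same change would give a similar step with (5-methyl-1H-imidazol-4-yl)methyl on the nitrogen remains open. So does the effect of other groups at the same place, such as a chlorine atom, a nitrile or a methoxy group.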